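The source may hold more compounds than are shown below. What is called first, only, known or untested is meant among the compounds shown, and "the series" means these compounds.

Of the compounds shown here, three sharing one core have been measured in a functional assay on A549 cells (Homo sapiens) for antiproliferative activity, read by MTT assay, with a stated time of 72 h; a higher number here means a weaker inhibitor, a lower number a stronger inhibitor. Compound 1 `O=C(Nc1ccc(CN2CCCCC2)cc1)Nc1ccc2ncnc(Nc3cccc(C(F)(F)F)c3)c2c1` gives 1050 nM, compound 2 `O=C(Nc1ccc(CN2CCCC2)cc1)Nc1ccc2ncnc(Nc3cccc(C(F)(F)F)c3)c2c1` gives 830 nM, and compound 3 `CN(C)Cc1ccc(NC(=O)Nc2ccc3ncnc(Nc4cccc(C(F)(F)F)c4)c3c2)cc1` gives 1120 nM, the highest number of the three, though its gaps to the others lie within the scatter. The steps of a 1.3-fold lower number from compound 1 to compound 2 (0.10 log units; within the scatter), a 1.1-fold higher number from compound 1 to compound 3 (0.03 log units; within the scatter) and a 1.3-fold higher number from compound 2 to compound 3 (0.13 log units; within the scatter) all exchange one amine for another on a saturated chain carbon bound to an aromatic carbon, and none left the scatter. Compound 4 `Cc1ccc(NC(=O)Nc2ccc3ncnc(Nc4cccc(C(F)(F)F)c4)c3c2)cc1` carries the change (hydrogen in place of dimethylamino on a saturated chain carbon bound to an aromatic carbon), removing the amine rather than swapping it. Since the three measured steps concern the same position, a modest step is expected in this assay, estimated as a 1.3-fold higher number from compound 3 to compound 4 (0.13 log units; within the scatter). Compound 4 is expected to give about 1500 nM, with a range from 500 nM to 5000 nM.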

Compound 4, half-maximal inhibitory concentration: 4140 nM
Beside the measured number, compound 4's estimate is 2.8-fold (0.44 log units) below it; measured number inside the range.
By their numbers in this assay, from the lowest: compounds 2, 1 and 3 (each within the scatter of the next); then compound 4.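

In this assay, this position did not respond to exchanging one amine for another, but it does respond to losing the amine altogether. Hydrogen in its place gives (a 3.7-fold higher number from compound 3 to compound 4 (0.57 log units; beyond the scatter)), (a 3.9-fold higher number from compound 1 to compound 4 (0.60 log units; beyond the scatter)) and (a 5.0-fold higher number from compound 2 to compound 4 (0.70 log units; beyond the scatter)), all beyond the scatter, which leaves compound 4 the weakest of the four. No measurement shown gives a reason for this loss. On these data alone, it remains open whether a morpholine, a hydroxyl or a carboxylic acid on that saturated chain carbon would behave like the amines or like hydrogen, and whether a longer chain carrying the dimethylamino would do the same.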